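This account rests on a few compounds, and the source may have more. Where it says the series, first, only, none or still open, it means among the compounds named here.

Measured so far:
compound 1 `C=C[C@@](C)(/C=C/c1ccc(OC)cc1)CCC=C(C)C` — > 26000 nM
compound 2 `C=C[C@@](C)(/C=C/c1ccc(O)c(/C=C/C(=O)O)c1)CCC=C(C)C` — > 26000 nM
compound 3 `COc1ccc(/C=C/[C@@](C)(/C=C/c2ccc(O)c(/C=C/C(=O)OCc3ccccc3)c2)CCC=C(C)C)cc1` — > 26000 nM

In a functional assay on Raji cells (Homo sapiens) for cytotoxicity, with a stated time of 72 h (a higher number here means that more compound is needed for the effect, a lower number that less compound is needed), compound 1 gives > 26000 nM, which is a limit of the assay and not a number. Compound 2 gives > 26000 nM, also a limit. Compound 3 gives > 26000 nM, again a limit. Compound 1 therefore stands where all three sit, at the limit of > 26000 nM in this assay, at which 3 of the 3 values shown sit, and none of the three can be ordered against another. Compound 4 `C=C[C@@](C)(/C=C/c1ccc(-c2ccccc2)cc1)CCC=C(C)C` has not yet been measured in this assay; it differs from compound 1 by phenyl in place of methoxy on an aromatic carbon. Among the compounds with values here, no step between measured compounds is available to gauge this change, so in this assay the expected step that the limit leaves unreadable from compound 1 to compound 4 is none beyond the scatter. Compound 4 is thus estimated at 30000 nM, with a range from 8000 nM to 100000 nM.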

Compound 4, half-maximal effective concentration: > 26000 nM
Compound 4: no number, only a limit; the forecaster's own chance of this, stated with the estimate: 70%; the middle value lies beyond the limit too.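

Within the data shown here, compound 4, like compound 1, gives only a limit, so no step between these two compounds can be read in this assay: the limit of > 26000 nM in this assay, at which 4 of the 4 values shown sit. The compounds shown leave open whether phenyl in place of methoxy changes cytotoxicity, and how far any compound lies beyond that limit.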